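The source may report more compounds than this note shows. Statements on the series, on what has been measured and on what is new or still open speak of the compounds shown alone.

Compound 2 `CCCSc1nc(Cl)c2c(n1)N(Cc1cccs1)C(C(=O)N1CCN(C)CC1)N2` gives 39400 nM in a functional assay on TE-1 cells (Homo sapiens) for antiproliferative activity, read by MTT assay, with a stated time of 72 h (a higher number here means a weaker inhibitor, a lower number a stronger inhibitor), the lowest of the two numbers measured, though its nearest neighbour compound 1 `CCCSc1nc(Cl)c2c(n1)N(CCNC(=O)OC(C)(C)C)C(C(=O)N1CCN(C)CC1)N2` with 51800 nM stands within the scatter of it. Compound 3 `CCCSc1nc(Cl)c2c(n1)N(Cc1ccccc1)C(C(=O)OCC)N2` reaches only a limit of the assay, > 64000 nM, in this assay. Going by the values given here, the one measured step with a full number at each end, a 1.3-fold lower number from compound 1 to compound 2 (0.12 log units; within the scatter), stays within the scatter. Compound 4 `CCCSc1nc(Cl)c2c(n1)N(Cc1ccco1)C(C(=O)N1CCN(C)CC1)N2` differs from compound 2 in one place: furan-2-yl in place of thiophen-2-yl on a saturated chain carbon bound to a nitrogen on an aromatic ring in a ring. No measured step tests this swap, and the only step shown was flat, so the number for compound 4 is expected to sit close to that of compound 2, with a 1.0-fold higher number from compound 2 to compound 4 (0.01 log units; within the scatter) expected to stay within the scatter. Compound 4 is therefore estimated at 40000 nM, between 18000 nM and 90000 nM in this assay.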

Compound 4, half-maximal inhibitory concentration: 35000 nM
The estimate for compound 4 lay 1.1-fold (0.06 log units) above the measured number, within the range that was stated.
By their numbers in this assay, from the lowest: compounds 4, 2 and 1 (each within the scatter of the next). At a limit, above all of these: compound 3.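

In this assay, going by these compounds alone, a 1.1-fold lower number from compound 2 to compound 4 (0.05 log units; within the scatter), so at this position a furan-2-yl group and a thiophen-2-yl group cannot be told apart, a sulfur-for-oxygen exchange the earlier compounds did not test. The wider replacement reads the same way: a 1.5-fold lower number from compound 1 to compound 4 (0.17 log units; within the scatter). Nothing measured here gives a reason for these results. From the compounds shown here alone, whether a basic amine, a carboxylic acid or a longer chain on this saturated chain carbon would move the number beyond the scatter stays open.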